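The compounds below may be only part of what the source reports. "The series", "measured", "known", "first", "only" and "open" are said of these compounds alone.

Compound 3 `CSc1nc2cc(Cl)ccc2o1` is the bare core of the series with no chain on the sulfur. In an ADME assay on microsomes from liver (Mus musculus) for metabolic stability, read by LC-MS, using NADPH, with a stated time of 45 min, tested at 0.5 uM (on this read-out higher numbers stand for fast clearance and lower numbers for slow clearance), compound 3 gives > 46.1 mL/min/g, which is a limit of the assay rather than a number (the limit of > 46.1 mL/min/g in this assay, at which 1 of the 3 values shown sits). Two amides with the full chain are measured: compound 1 `O=C(CCSc1nc2cc(Cl)ccc2o1)N1CCS(=O)(=O)C1` gives 8.9 mL/min/g, and compound 2 `O=C(CCSc1nc2cc(Cl)ccc2o1)N1CCCCC1` gives 128 mL/min/g, so that the step of a 14-fold higher number from compound 1 to compound 2 (1.16 log units; beyond the scatter) is the only one in hand and it concerns the amide end alone. Compound 4 `CN(C)C(=O)CCSc1nc2cc(Cl)ccc2o1` carries (dimethylcarbamoyl)methyl in place of hydrogen on a saturated chain carbon bound to a sulfur. Going by the values given here, no measured step starts from compound 3, so the change from compound 3 to compound 4 has no direct precedent. Compound 4 is expected to move by a step that the limit leaves unreadable from compound 3 to compound 4. The estimate for compound 4 is 60 mL/min/g, between 20 mL/min/g and 160 mL/min/g.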

Compound 4, intrinsic clearance in a liver preparation (reported as CLH), per the amount of preparation that the assay uses: 41.8 mL/min/g
The estimate for compound 4 lay 1.4-fold (0.16 log units) above the measured number; the range from low to high includes it.
By their numbers in this assay, from the lowest: compound 1; then compound 4; then compound 2.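

In this assay, the amide end now has a third member, and the dimethylamino amide falls within the range set by the earlier pair: a 3.1-fold lower number from compound 2 to compound 4 (0.49 log units; beyond the scatter) and a 4.7-fold higher number from compound 1 to compound 4 (0.67 log units; beyond the scatter). Both steps are modest and beyond the scatter, so the amide end gives a graded order rather than two extremes. The step from the bare core reads only as an at least 1.1-fold lower number from compound 3 to compound 4 (0.04 log units; that floor lies within the scatter). The value of compound 3 is a limit and not a number: the limit of > 46.1 mL/min/g in this assay, at which 1 of the 4 values shown sits.

Still open, as far as these compounds go, is whether a morpholin-4-yl amide would stay nearer compound 1 or compound 2. Also open, from the compounds shown here alone, is how a longer chain on the sulfur would shift the number.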